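Adding One Chloro Group to Compound 2

The compounds below may be only part of what the source reports. "The series", "measured", "known", "first", "only" and "open" are said of these compounds alone.

Compound 1 (`O=C(Nc1ccc(Cl)c(Cl)c1)c1cc(F)ccc1O`) and compound 2 (`O=C(Nc1cccc(C(F)(F)F)c1)c1cc(F)ccc1O`) share the same core. In a functional assay on HL-60 cells (Homo sapiens) for cytotoxicity, read by luminescence and CellTiter-Glo, with a stated time of 3 days (a lower number here means a stronger inhibitor, a higher number a weaker inhibitor), compound 1 gives 660 nM, and compound 2 gives 970 nM. These two numbers lie within the usual scatter of each other, so compound 2 stands level with compound 1 and neither can be ranked over the other.

Compound 3 (`O=C(Nc1ccc(Cl)c(C(F)(F)F)c1)c1cc(F)ccc1O`) differs from compound 2 in one place: chloro in place of hydrogen on an aromatic carbon. In words, this is chloro in place of hydrogen on an aromatic carbon, ortho to a trifluoromethyl group and para to a large group. Among the measured compounds shown here, no pair of measured compounds shows this change alone, so the data offer no direct guide to its size. A small move towards a lower number in this assay is expected, close to the limit of the scatter. That cautious lean rests on compound 1, which also carries chloro and gives 660 nM. The expected size of the change is a 1.9-fold lower number from compound 2 to compound 3 (0.29 log units; within the scatter). For compound 3 the estimated value is 500 nM, within a range from 180 nM to 1200 nM.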

Compound 3, half-maximal inhibitory concentration: 600 nM
Estimate against measurement, compound 3: 1.2-fold (0.08 log units) below; the measured number falls inside the stated range.
By their numbers in this assay, from the lowest: compounds 3, 1 and 2 (each within the scatter of the next).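

In this assay, putting chloro on this aromatic carbon, ortho to a trifluoromethyl group and para to a large group, gives a 1.6-fold lower number from compound 2 to compound 3 (0.21 log units; within the scatter) and so leaves compound 3 level with compound 2 as far as this assay can tell. Compound 3 can also be read against compound 1, where trifluoromethyl in place of chloro on an aromatic carbon gives a 1.1-fold lower number from compound 1 to compound 3 (0.04 log units; within the scatter) and the two groups cannot be told apart in this assay. Nothing measured alongside these compounds bears on what lies behind these two small steps.

Both steps stay within the scatter, so the compounds shown do not reveal whether a change at this carbon can shift the number by a clear margin, for example with an amine, a carboxylic acid or a longer chain such as propyl in place of chloro. They also leave open whether chloro at this carbon would give a similar step on a molecule that has some other group in place of the trifluoromethyl group.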